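The source may report more compounds than this note shows. Statements on the series, on what has been measured and on what is new or still open speak of the compounds shown alone.

Measured so far in an ADME assay on MDBK cells (Bos taurus) for cytotoxicity; on this read-out higher numbers stand for lower toxicity in this test and lower numbers for higher toxicity in this test:

compound 1 `Cc1cc(C(C)(C)c2ccc(OCC(=O)C(C)(C)C)c(C)c2)ccc1OCC(=O)C(C)(C)C` gives > 100000 nM
compound 2 `Cc1cc(C2(c3ccc(OCC(=O)C(C)(C)C)c(C)c3)CCC2)ccc1OCC(=O)C(C)(C)C` gives > 100000 nM
compound 3 `CC[Si](CC)(c1ccc(OCC(=O)C(C)(C)C)cc1)c1ccc(OCC(=O)C(C)(C)C)cc1` gives > 100000 nM

Each of these entries is a limit of the assay and not a number, so the three compounds cannot be ranked against one another. Compound 3 stands at > 100000 nM in this read-out, and that is a limit. Compound 1 and compound 2 share this position, as the limit of > 100000 nM in this assay, at which 3 of the 3 values shown sit, makes clear.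

The next compound is compound 4 `CC[Si](CC)(c1ccc(O)cc1)c1ccc(OCC(=O)C(C)(C)C)cc1`, which differs from compound 3 in one place. On an oxygen on an aromatic ring, hydrogen comes in place of ((tert-butyl)carbonyl)methyl (hydrogen in place of ((tert-butyl)carbonyl)methyl on an oxygen on an aromatic ring), so that ((tert-butyl)carbonyl)methoxy becomes hydroxy.

Within the data shown here, no two measured compounds differ in one place, and none of them carries this hydroxy, so the data give no size for such a change. The expectation is therefore a cautious one: a modest move toward lower numbers, meaning somewhat higher toxicity in this test, though a result that stays at the limit is just as plausible. The estimated step is an at least 1.6-fold lower number from compound 3 to compound 4 (0.22 log units; that floor lies within the scatter) and it should be read as a rough guess. Compound 4 is estimated at 60000 nM with an expected range of 15000 nM to 100000 nM in this assay when it is measured.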

Compound 4, half-maximal cytotoxic concentration: 46800 nM
The estimate for compound 4 lay 1.3-fold (0.11 log units) above the measured number; the range from low to high includes it.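

In this assay, hydrogen in place of ((tert-butyl)carbonyl)methyl on an oxygen on an aromatic ring gives an at least 2.1-fold lower number from compound 3 to compound 4 (0.32 log units; beyond the scatter). This shows that the position matters in this test: turning ((tert-butyl)carbonyl)methoxy into hydroxy moves the read-out toward higher toxicity, and compound 4 is the first compound shown to give a number rather than a limit, which offers a measured point for comparing further changes. The full size of the step remains unknown, because its starting value is a limit: the limit of > 100000 nM in this assay, at which 3 of the 4 values shown sit.

On these data alone, this is a single pair, so it remains open whether the same change would have a similar effect on the cores of compound 1 or compound 2, or whether replacing the remaining ((tert-butyl)carbonyl)methyl on compound 4 with hydrogen would move the number further. As far as these compounds go, it also remains open whether a small methyl ether on that oxygen, or an amine in place of the hydroxy, would give a number closer to that of compound 4 or stay at the limit seen for compound 3.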